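A few compounds are considered here, and "the series" means these few. Any claim that something is new, unique, unknown or untested is made for them only; others in the source may bear on it.

Working notes on the series. Compound 1 `O=C1NC(=S)S/C1=C\C=C\c1ccccc1` and compound 2 `O=C1NC(=O)/C(=C/C=C/c2ccccc2OCc2ccccc2Br)S1` have been run in a functional assay on DLD-1 cells (Homo sapiens), read by microscopy and crystal violet staining, with a stated time of 20 h, tested at 10 ug/mL; a higher number here means more inhibition at the concentration tested (going by the name of the read-out), a lower number less inhibition. In this assay compound 1 gives 81%, and compound 2 gives 50%, a number lower by a gap beyond the scatter, which leaves compound 1 with the higher of the two numbers. Compound 3 `COc1ccccc1/C=C/C=C1\SC(=S)NC1=O` is not yet measured; it differs from compound 1 by methoxy in place of hydrogen on an aromatic carbon. For the measured compounds named here, no measured pair isolates this change, so its size is open. A small downward step, or none beyond the scatter, is expected, as in a number 9 percentage points lower from compound 1 to compound 3 (within the scatter). For compound 3 the estimate in this assay is 72%, with a range from 50% to 90%.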

Compound 3, a percentage reported as inhibition, at one concentration (the size of the read-out at that concentration, not a potency): 69%
For compound 3 the middle estimate is 3 percentage points above the measured one; measured number inside the range.
By their numbers in this assay, from the lowest: compound 2; then compound 3; then compound 1.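

In this assay, for the compounds shown here, this is the first pair to isolate the change, and it gives a number 12 percentage points lower from compound 1 to compound 3 (beyond the scatter). Methoxy in place of hydrogen on an aromatic carbon, ortho to a large group, therefore lowers the inhibition at the concentration tested by a modest step and leaves much of it in place. Nothing at hand bears on the reason for this step. Open, on these data alone, is whether an amine, a carboxylic acid or a longer ether chain at this place would give a step of like size. Also open, as far as these compounds go, is whether methoxy elsewhere on the same ring would match it.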